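A few compounds are considered here, and "the series" means these few. Any claim that something is new, unique, unknown or untested is made for them only; others in the source may bear on it.

Compound 3 `Nc1ccc(-c2nc3cc(Cl)c(Cl)cc3[nH]2)cc1` stands highest of the two numbers recorded in an ADME assay on MT4 cells (Homo sapiens) for cytotoxicity, read by MTT assay, with a stated time of 96 h (on this read-out higher numbers stand for lower toxicity in this test and lower numbers for higher toxicity in this test), where compound 3 gives 17000 nM. Its nearest neighbour is compound 1 `COc1ccc(-c2nc3cc(Cl)c(Cl)cc3[nH]2)cc1`, which in this assay gives 1000 nM. Compound 2 `Cn1c(-c2ccc([N+](=O)[O-])cc2)nc2cc(C(F)(F)F)ccc21` reaches only a limit of the assay in this assay, namely >= 100000 nM. Compound 4 `Oc1ccc(-c2nc3cc(Cl)c(Cl)cc3[nH]2)cc1` has not yet been measured; it differs from compound 3 as follows: hydroxy in place of amino on an aromatic carbon. The only measured step among these compounds is a 17-fold higher number from compound 1 to compound 3 (1.23 log units; beyond the scatter), which runs the other way, from methoxy to amino, and no measured step exchanges amino for hydroxy. With nothing closer to lean on, a step of moderate size back toward compound 1 is expected, a 2.1-fold lower number from compound 3 to compound 4 (0.33 log units; beyond the scatter). Compound 4 is therefore expected to give 8000 nM in this assay, within 2500 nM to 25000 nM.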

Compound 4, half-maximal cytotoxic concentration: 12000 nM
Beside the measured number, compound 4's estimate is 1.5-fold (0.18 log units) below it, within the range that was stated.
By their numbers in this assay, from the lowest: compound 1; then compounds 4 and 3 (each within the scatter of the next). At a limit, above all of these: compound 2.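

Hydroxy and amino on an aromatic carbon para to a large group cannot be told apart in this assay, since the exchange gives a 1.4-fold lower number from compound 3 to compound 4 (0.15 log units; within the scatter). Hydrogen in place of methyl on the oxygen counts for far more, with a 12-fold higher number from compound 1 to compound 4 (1.08 log units; beyond the scatter), so methoxy alone stands apart among these three compounds. Nothing measured here accounts for this result. From the compounds shown here alone, it remains open whether ethoxy at this place would follow methoxy, and whether a carboxylic acid or an acetamide would stay with hydroxy and amino.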